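Acetyl to Benzoyl: Expected Effect on Growth Inhibition

A few compounds are considered here, and "the series" means these few. Any claim that something is new, unique, unknown or untested is made for them only; others in the source may bear on it.

Of the compounds shown here, three sharing one core have been tested in a functional assay on COLO 205 cells (Homo sapiens) for inhibition, read by sulforhodamine B assay, with a stated time of 48 h; a higher number here means a weaker inhibitor of growth, a lower number a stronger inhibitor of growth. Compound 1 `COc1ccc(-c2[nH]c3ccccc3c2/C=C(\C#N)S(=O)(=O)c2ccccc2)cc1` gives 254 nM. Compound 2 `COc1ccc2[nH]c(-c3ccccc3)c(C=C(C#N)C#N)c2c1` gives 2100 nM in this assay. Compound 3 `CC(=O)/C(=C\c1c(-c2ccccc2)[nH]c2ccccc12)S(=O)(=O)c1ccccc1` gives 1700 nM in this assay, the second highest of the three numbers; it lies within the scatter of compound 2 but beyond the scatter of compound 1, which shows a clearly lower number.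

Compound 4 `O=C(/C(=C\c1c(-c2ccccc2)[nH]c2ccccc12)S(=O)(=O)c1ccccc1)c1ccccc1` is not yet measured. It differs from compound 3 by phenyl in place of methyl on a carbonyl carbon. Among the compounds with values here, no step between two measured compounds mirrors this change, so there is no direct guide. A modest downward step is expected, of about a 1.9-fold lower number from compound 3 to compound 4 (0.28 log units; within the scatter), though it may fall within the scatter. Compound 4 is estimated at 900 nM, within a range from 250 nM to 3500 nM.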

Compound 4, concentration for 50% growth inhibition: 7800 nM
Compound 4: middle estimate off by 8.7-fold (0.94 log units), on the low side; the whole stated range lies below it.
By their numbers in this assay, from the lowest: compound 1; then compounds 3 and 2 (each within the scatter of the next); then compound 4.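

Within the data shown here, compound 3 and compound 4 form the first measured pair that differ in one place, and the change from acetyl to benzoyl brings a 4.6-fold higher number from compound 3 to compound 4 (0.66 log units; beyond the scatter). So growth inhibition responds to the group on this carbonyl carbon, and in this single pair the phenyl goes with the weaker inhibitor. No measurement shown here explains the step.
On these data alone, it remains open whether an ethyl or a longer chain in place of methyl would stay close to compound 3. An amine on this carbonyl carbon is also an open case.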